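A Methyl Added to Compound 2

The source may report more compounds than this note shows. Statements on the series, on what has been measured and on what is new or still open speak of the compounds shown alone.

Compound 2 `N/C(=N\NC(=S)N1CCCC1)c1ccccn1` gives 87.8% in a functional assay on A-375 cells (Homo sapiens) for cytotoxicity, read by MTT assay, with a stated time of 72 h, tested at 100 uM; a lower number here means less inhibition of growth, a higher number more inhibition of growth at the concentration tested. Among the compounds with values here, compound 1 `Cc1ccnc(/C(N)=N/NC(=S)N2CCSCC2)c1` gives 89.9% in this assay, the only other number, and it lies within the scatter of the value of compound 2. Compound 3 `Cc1ccnc(/C(N)=N/NC(=S)N2CCCC2)c1` has not yet been measured; it differs from compound 2 by methyl in place of hydrogen on an aromatic carbon. Within the data shown here, no step between two measured compounds is available here, so no direction can be read from the data. The step of a number 0.2 percentage points higher from compound 2 to compound 3 (within the scatter) is expected to be none beyond the scatter. Compound 3 is therefore estimated at 88%, with a range from 78% to 96%.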

Compound 3, percent growth inhibition at one concentration: 88.8%
The estimate for compound 3 lay 0.8 percentage points below the measured number; the range from low to high includes it.
By their numbers in this assay, from the lowest: compounds 2, 3 and 1 (each within the scatter of the next).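

In this assay, methyl in place of hydrogen on the aromatic carbon opposite the ring nitrogen gives a number 1 percentage points higher from compound 2 to compound 3 (within the scatter), so the number at this position stays level with that of the unsubstituted ring. Pyrrolidin-1-yl in place of thiomorpholin-4-yl on the thiocarbonyl carbon gives a number 1.1 percentage points lower from compound 1 to compound 3 (within the scatter), which is the first single-place comparison at that carbon and likewise shows no separation. Nothing given here bears on the reason for either result.

Going by these compounds, whether an amine, a carboxylic acid or a longer chain on this aromatic carbon would hold the number stays open. On these data alone, with a single tested concentration, how these compounds would separate at lower concentrations also stays open.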